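A Second Fluorine on the Sulfonyl Ring

The compounds below may be only part of what the source reports. "The series", "measured", "known", "first", "only" and "open" are said of these compounds alone.

Compound 2 `COc1ccc(-c2c(S(=O)(=O)c3cccc(F)c3)cnc3c(F)cccc23)cc1` and compound 1 `O=S(=O)(c1ccc(F)c(F)c1)c1cnc2c(F)cccc2c1-c1ccc(Cl)cc1` share a core but differ at two places. In an ADME assay on microsomes from liver (Homo sapiens) for metabolic stability, tested at 2.5 uM (on this read-out lower numbers stand for slow clearance and higher numbers for fast clearance), compound 2 gives 2.48 mL/min, the higher of the two numbers seen so far, while compound 1 gives 0.28 mL/min; the gap between them is beyond the usual scatter, yet since these two compounds differ at more than one place, the values alone cannot be tied to either single change. Compound 3 `COc1ccc(-c2c(S(=O)(=O)c3ccc(F)c(F)c3)cnc3c(F)cccc23)cc1` is compound 2 with one alteration only: fluoro in place of hydrogen on an aromatic carbon. Among the measured compounds shown here, no measured pair here isolates this change, so the size of the step is uncertain. The expected step of a 1.4-fold lower number from compound 2 to compound 3 (0.14 log units; within the scatter) in this assay is a modest fall that may well remain within the scatter. Compound 3 is therefore estimated at 1.8 mL/min in this assay, with a range from 0.8 mL/min to 3.5 mL/min.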

Compound 3, intrinsic clearance in a liver preparation (reported as CLH), per the amount of preparation that the assay uses: 2.12 mL/min
Estimate against measurement, compound 3: 1.2-fold (0.07 log units) below, within the range that was stated.
By their numbers in this assay, from the lowest: compound 1; then compounds 3 and 2 (each within the scatter of the next).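

Putting fluoro in place of hydrogen, which turns 3-fluorophenyl into 3,4-difluorophenyl, gives a 1.2-fold lower number from compound 2 to compound 3 (0.07 log units; within the scatter) in this assay, so at this place on the ring the added fluoro does not separate the two compounds. The other single change, methoxy in place of chloro on an aromatic carbon, gives a 7.6-fold higher number from compound 1 to compound 3 (0.88 log units; beyond the scatter), so among these three compounds the large gap follows the methoxy and chloro swap and not the fluoro. Nothing available here explains either step.

As far as these compounds go, whether the fluoro step stays this small when chloro replaces methoxy remains open, as does the size of the methoxy and chloro step with a 3-fluorophenyl group. From the compounds shown here alone, how an amine or a nitrile would read at the fluoro position also remains unknown.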